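The compounds below may be only part of what the source reports. "The series", "measured", "known", "first", "only" and "open" are said of these compounds alone.

Compound 1 `COc1cccc(C#Cc2csc(C)n2)c1` gives 49 nM in a functional assay on CHO cells for agonist activity at metabotropic glutamate receptor 5 (Homo sapiens), read by inositol phosphate accumulation (on this read-out higher numbers stand for weaker inhibition and lower numbers for stronger inhibition), the lowest of the three numbers in hand. Compound 3 `Cc1nc(C#Cc2cccc(Cl)c2)cs1` gives 129 nM and compound 2 `Cc1nc(C#Cc2ccccc2F)cs1` gives 140 nM, each beyond the scatter from compound 1. Compound 4 `CC(=O)Nc1cccc(C#Cc2csc(C)n2)c1` carries acetamido in place of methoxy on an aromatic carbon. Going by the values given here, the only measured step at this position is a 2.6-fold higher number from compound 1 to compound 3 (0.42 log units; beyond the scatter), a modest rise; compound 2 differs from compound 1 in more than one place and merely shows a higher number. Acetamido has no precedent in the series, so only a small step is expected in this assay, most likely toward a higher number, as a 2.0-fold higher number from compound 1 to compound 4 (0.31 log units; beyond the scatter). Compound 4 is therefore estimated at 100 nM, within a range of 30 nM to 400 nM.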

Compound 4, half-maximal inhibitory concentration: 2020 nM
Estimate against measurement, compound 4: 20-fold (1.31 log units) below, and the stated range ends below it.
By their numbers in this assay, from the lowest: compound 1; then compounds 3 and 2 (each within the scatter of the next); then compound 4.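

Acetamido on this aromatic carbon brings a 41-fold higher number from compound 1 to compound 4 (1.62 log units; beyond the scatter) and a 16-fold higher number from compound 3 to compound 4 (1.19 log units; beyond the scatter) in this assay, so this position does not accept every replacement of methoxy with only a modest change, as chloro alone had suggested. Acetamido differs from methoxy in both size and its hydrogen-bond donor, and these compounds do not separate the two. No measured evidence explains the rise.

On these data alone, it remains open whether an amine, which keeps a hydrogen-bond donor with fewer heavy atoms than acetamido, would give a similar number. The same question stands for ethoxy, a longer ether without that donor.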